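The source may hold more compounds than are shown below. What is called first, only, known or untested is meant among the compounds shown, and "the series" means these compounds.

In a functional assay on HeLa cells (Homo sapiens) for inhibition, read by WST assay, with stated times of 72 h and 2 h (a lower number here means a stronger inhibitor, a higher number a weaker inhibitor), compound 1 (`OC(c1cccs1)c1cc2ccccc2nc1Cl`) gives 17500 nM and compound 2 (`C#CCOC(c1cccs1)c1cc2ccccc2nc1Cl`) gives 34700 nM in the same read-out. Going by the values given here, the only measured step is a 2.0-fold higher number from compound 1 to compound 2 (0.30 log units; within the scatter), with propargyl in place of hydrogen on an oxygen on a saturated carbon. Compound 3 (`Cc1ccc(-c2cc(COC(c3cccs3)c3cc4ccccc4nc3Cl)on2)cc1`) has no single number: compound 3 is reported as "not active" (no number reported) in this assay, which leaves no value to count a step from.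

Compound 4 (`Oc1ccc(-c2cc(COC(c3cccs3)c3cc4ccccc4nc3Cl)on2)cc1`) changes one place in compound 3: hydroxy in place of methyl on an aromatic carbon, that is, 4-methylphenyl to 4-hydroxyphenyl. The step from compound 1 to compound 2 lies elsewhere in the structure and bears on this change only loosely. Among the compounds with values here, no measured step gives its size, so no definite step or direction is expected in this assay. Weak inhibition is expected to persist, and a report without a number remains a real possibility. Compound 4 is estimated at 40000 nM, with an expected range from 15000 nM to 100000 nM.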

Compound 4, half-maximal inhibitory concentration: "not active" (no number reported)
The entry for compound 4 holds no number; no gap can be computed for the estimate.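

In this assay, going by these compounds alone, compound 3 and compound 4 are both reported as not active, without a number, so no step between them can be read. No evidence bears on this result. The compounds shown leave open what effect, if any, the change from 4-methylphenyl to 4-hydroxyphenyl has on inhibition.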